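A few compounds are considered here, and "the series" means these few. Any claim that something is new, unique, unknown or untested is made for them only; others in the source may bear on it.

Compound 1 `CCCCCCCCOP(=O)(O)OCCSC(=S)N1CCN(C)CC1`: 46000 nM
Compound 2 `CCCCCCOP(=O)(O)OCCSC(=S)N1CCN(C)CC1`: 58000 nM

Both values come from a functional assay on MCF7 cells (Homo sapiens) for inhibition, read by MTT assay, with stated times of 18 h and 4 h (on this read-out lower numbers stand for stronger inhibition and higher numbers for weaker inhibition), and lie within the usual scatter of each other, so compound 2 has no separate place on the numbers and stands level with compound 1. Still unmeasured is compound 3 `CCCOP(=O)(O)OCCSC(=S)N1CCN(C)CC1`, which differs from compound 2 as follows: hydrogen in place of propyl on a saturated chain carbon, three bonds along the chain from an oxygen on an unsaturated carbon. Seen one bond further out, this reads hexyl to propyl.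

Among the compounds with values here, the one measured step that bears on this is a 1.3-fold higher number from compound 1 to compound 2 (0.10 log units; within the scatter) and it is small, for hydrogen in place of ethyl on a saturated chain carbon, six bonds along the chain from an oxygen on an unsaturated carbon. A single pair is thin evidence, and the new change sits at a different place on the chain, so the step may not carry over. Starting from compound 2 at 58000 nM and given that small step, a slight move to a higher number, meaning weaker inhibition, is expected, probably not clearly beyond the scatter. The estimated step is a 1.3-fold higher number from compound 2 to compound 3 (0.11 log units; within the scatter) on this reasoning. For compound 3 the expected value is 75000 nM with an estimated range from 40000 nM to 160000 nM in this assay as well.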

Compound 3, half-maximal inhibitory concentration: 59000 nM
Compound 3: middle estimate off by 1.3-fold (0.10 log units), on the high side; the range from low to high includes it.
By their numbers in this assay, from the lowest: compounds 1, 2 and 3 (each within the scatter of the next).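

Moving from hexyl to propyl, three bonds along the chain from an oxygen on an unsaturated carbon, gives a 1.0-fold higher number from compound 2 to compound 3 (0.01 log units; within the scatter) in this assay and so shows that this much shorter chain still reads level with the hexyl compound. Within the data shown here, replacing pentyl with hydrogen at that same place gives a 1.3-fold higher number from compound 1 to compound 3 (0.11 log units; within the scatter) and extends the picture, since all three compounds now sit within the scatter of one another and none of the three goes against a flat reading across these chain lengths, a broader view than the single small step available earlier could give. No measured evidence is at hand to explain this flat reading. The compounds shown leave open whether a much longer chain, or an amine or a carboxylic acid placed on the chain, would move the number clearly beyond the scatter. They also share the rest of the core, so they cannot tell how much changes there would matter in this cell assay.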